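This account rests on a few compounds, and the source may have more. Where it says the series, first, only, none or still open, it means among the compounds named here.

Among the compounds with values here, compound 3, `COC(=O)C1=C(C)N(C)C(=O)NC1c1ccsc1`, stands second of the three compounds measured so far. In an assay on membranes from CHO cells for displacement of a labelled ligand from adenosine receptor A1 (Homo sapiens), read by scintillation counting, with a stated time of 60 min, tested at 1 uM (on this read-out lower numbers stand for less inhibition and higher numbers for more inhibition at the one concentration tested (going by the name of the read-out)), compound 3 gives 24%. Compound 1, `COC(=O)C1=C(C)N(C)C(=O)NC1c1ccco1`, gives 45%, and compound 2, `CC1=C(C(=O)OCC(C)C)C(c2ccco2)NC(=O)N1C`, gives 13%; the step of a number 21 percentage points lower from compound 1 to compound 3 (beyond the scatter) lies beyond the scatter, as does the smaller gap that separates compound 3 from compound 2.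

Compound 4, `CC1=C(C(=O)OCC(C)C)C(c2ccsc2)NC(=O)N1C`, is not yet measured. It differs from compound 3 in one place: isopropyl in place of hydrogen on a saturated chain carbon bound to an oxygen next to a carbonyl group. The same change has been made once before among the measured compounds, going from compound 1 to compound 2, where it gave a number 32 percentage points lower from compound 1 to compound 2 (beyond the scatter). Within the data shown here, that single step is the only guide available, and it points downward by a wide margin.

Compound 3 starts lower than compound 1 did, so a fall of the same size would carry the number toward zero, where the read-out has little room left to drop. The expected change is therefore a number 21 percentage points lower from compound 3 to compound 4 (beyond the scatter), a clear fall ending near no inhibition at the tested concentration. In this assay compound 4 is estimated to give 3%, with a range from -10% to 16%.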

Compound 4, a percentage reported as inhibition, at one concentration (the size of the read-out at that concentration, not a potency): 8%
Compound 4: middle estimate off by 5 percentage points, on the low side, within the range that was stated.
By their numbers in this assay, from the lowest: compounds 4 and 2 (each within the scatter of the next); then compound 3; then compound 1.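

In this assay, the isopropyl change lowers the number again, a number 16 percentage points lower from compound 3 to compound 4 (beyond the scatter), so the fall at this saturated chain carbon is not confined to the furan-2-yl compounds, although its size differs between the two cores: the same change on two cores in this assay, a number 32 percentage points lower (beyond the scatter) from compound 1 to compound 2 and a number 16 percentage points lower (beyond the scatter) from compound 3 to compound 4, 16 percentage points apart, beyond the scatter of two such steps Read the other way, thiophen-3-yl in place of furan-2-yl now makes a step that stays inside the usual scatter, a number 5 percentage points lower from compound 2 to compound 4 (within the scatter), and this step too differs in size from the one seen earlier: the same change on two cores in this assay, a number 21 percentage points lower (beyond the scatter) from compound 1 to compound 3 and a number 5 percentage points lower (within the scatter) from compound 2 to compound 4, 16 percentage points apart, beyond the scatter of two such steps The two changes therefore do not simply add up, since each takes away less when the other is already in place than when it is made on compound 1.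

Compound 2 and compound 4 both lie close to no inhibition at the one concentration tested, so these percentages cannot tell whether the smaller steps belong to the groups themselves or only reflect the little room left near zero. From the compounds shown here alone, how ethoxycarbonyl, a shorter chain than isobutoxycarbonyl, or a carboxylic acid in place of methoxycarbonyl would read in this assay also stays open.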